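Compound 3 to compound 4: one group exchanged

The source may hold more compounds than are shown below. What is called first, only, known or untested is meant among the compounds shown, and "the series" means these compounds.

In an ADME assay on microsomes from liver (Mus musculus) for metabolic stability, with a stated time of 10 min, tested at 0.5 uM (a lower number here means that less of the compound is left, a higher number that more of the compound is left), compound 1 (`O=C(O)c1cccc2cc(Cn3ccc4ccncc4c3=O)oc12`) gives 96% and compound 2 (`O=C(O)c1cc(Cl)cc2cc(CNC(=O)c3cnn4cccnc34)oc12`) gives 100%, two numbers within the usual scatter of each other. Compound 3 (`C[C@@H](OC(=O)c1cc(Cl)cc2cc(CNC(=O)c3cnn4cccnc34)oc12)C(F)(F)F`) gives 0%, the lowest of the three and beyond the scatter from both.

Compound 4 (`O=C(NCc1cc2cc(Cl)cc(-c3nn[nH]n3)c2o1)c1cnn2cccnc12`) has not yet been measured. Its difference from compound 3 is this: 2H-tetrazol-5-yl in place of (1-(trifluoromethyl)ethoxy)carbonyl on an aromatic carbon. In short, 2H-tetrazol-5-yl stands in place of (1-(trifluoromethyl)ethoxy)carbonyl on an aromatic carbon.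

Among the measured compounds shown here, only one measured step bears on this change: a number 100 percentage points lower from compound 2 to compound 3 (beyond the scatter), where 1-(trifluoromethyl)ethyl replaces a hydrogen on an oxygen. That step is very large, and compound 4 no longer carries this 1-(trifluoromethyl)ethyl group. Neither of the high compounds carries it either, with compound 1 at 96% and compound 2 at 100%. A large rise is therefore expected, the reverse of the measured drop. For the measured compounds named here, no measured compound carries 2H-tetrazol-5-yl, however, so the effect of the entering group is untested and the range must stay wide.

The expected change is a number 90 percentage points higher from compound 3 to compound 4 (beyond the scatter). For compound 4 the estimate is 90%, with an expected range from 65% to 100%.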

Compound 4, percent of the compound remaining: 80%
Estimate against measurement, compound 4: 10 percentage points above; low and high end bracket the measured number.
By their numbers in this assay, from the lowest: compound 3; then compound 4; then compounds 1 and 2 (each within the scatter of the next).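

In this assay, 2H-tetrazol-5-yl on this aromatic carbon gives a number 80 percentage points higher from compound 3 to compound 4 (beyond the scatter), so the complete loss seen with (1-(trifluoromethyl)ethoxy)carbonyl does not carry over to this new group. Set against carboxy at the same place, however, the exchange gives a number 20 percentage points lower from compound 2 to compound 4 (beyond the scatter), which is modest but beyond the scatter; this is the first sign that the two groups are not interchangeable here, even though both leave far more compound than (1-(trifluoromethyl)ethoxy)carbonyl does. Nothing available explains either step.

Among the compounds shown here, with only three groups compared on this aromatic carbon, it remains open whether a primary amide or a nitrile there would match carboxy, fall to the level of 2H-tetrazol-5-yl or lie somewhere else. From the compounds shown here alone, it is also open whether 2H-tetrazol-5-yl would give a similar step against carboxy on the core of compound 1, which has no chloro group and carries a different side chain.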